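The source may report more compounds than this note shows. Statements on the series, on what has been measured and on what is new or still open speak of the compounds shown alone.

Measured so far in a physicochemical assay for solubility, read by nephelometry, measured as kinetic solubility, at pH 2.0; on this read-out higher numbers stand for higher solubility and lower numbers for lower solubility:
- compound 1 `NCc1csc(NC(=O)c2cnnn2Cc2ccccc2)n1`: > 100 ug/mL
- compound 2 `NCc1csc(NC(=O)c2ccc(Cl)cc2)n1`: > 100 ug/mL
- compound 3 `NCc1csc(NC(=O)c2cc3ccccc3o2)n1`: > 100 ug/mL

Each entry is a limit of the assay and not a number. In this assay compound 2 gives > 100 ug/mL, which is a limit, so its position within the series cannot be ranked. The series as a whole stands at the limit of > 100 ug/mL in this assay, at which 3 of the 3 values shown sit. Among the compounds with values here, no step between measured compounds is available, and the data therefore give no measured size of change for any substitution.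

The next compound is compound 4 `COc1ccc(C(=O)Nc2nc(CN)cs2)cc1`, which keeps the core of compound 2 and differs from it in one place: methoxy in place of chloro on an aromatic carbon. In words, this is methoxy in place of chloro on an aromatic carbon, para to a large group. The only basis for an expectation is that compound 2 gives > 100 ug/mL and that the series stands at the limit of > 100 ug/mL in this assay, at which 3 of the 3 values shown sit. No change beyond the usual scatter is expected for the estimated step that the limit leaves unreadable from compound 2 to compound 4. A report as a limit is the likeliest outcome in this assay. For compound 4 the estimated value is 110 ug/mL, with an expected range of 70 ug/mL to 200 ug/mL.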

Compound 4, solubility: 50 ug/mL
Beside the measured number, compound 4's estimate is 2.2-fold (0.34 log units) above it; the whole stated range lies above it.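

In this assay, within the data shown here, compound 4 gives 50 ug/mL, the first value that is a number and not a limit. Methoxy in place of chloro on this aromatic carbon, para to a large group, gives an at least 2.0-fold lower number from compound 2 to compound 4 (0.30 log units; that floor lies within the scatter), so a single change at this position can bring the read-out off the limit, although the floor of this step does not clear the usual scatter and the true size of the step cannot be read. All other values shown remain at one limit: the limit of > 100 ug/mL in this assay, at which 3 of the 4 values shown sit.

Going by these compounds, it remains open whether another group at this same place, such as an amine, a carboxylic acid or a longer alkoxy chain, would stay at the limit or give a number, and how far such a number would fall. Among these compounds, with only this one pair, it also remains open whether methoxy in place of chloro would give a similar result with the other amide portions, or with a group other than the aminomethyl on the shared core.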